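A 5-aminopyridin-3-yl isomer of compound 1

The source may report more compounds than this note shows. Statements on the series, on what has been measured and on what is new or still open speak of the compounds shown alone.

Three compounds have been measured in a physicochemical assay for solubility, read by LC-MS, in phosphate buffer, with a stated time of 24 h, at pH 6.8 (on this read-out higher numbers stand for higher solubility and lower numbers for lower solubility), so far:
Compound 1 `C[C@H](NC(=O)c1cccc(F)c1)c1ccc(NC(=O)N2CC(c3ccc(N)nc3)C2)cc1` gives 32000 nM
Compound 2 `C[C@H](NC(=O)C1CCOCC1)c1ccc(NC(=O)N2CC(c3ccc(N)nc3)C2)cc1` gives 310000 nM
Compound 3 `CCC(=O)N[C@@H](C)c1ccc(NC(=O)N2CC(c3ccc(N)nc3)C2)cc1` gives 760000 nM

Compound 1 has the lowest number of the three. Compound 4 `C[C@H](NC(=O)c1cccc(F)c1)c1ccc(NC(=O)N2CC(c3cncc(N)c3)C2)cc1` differs from it in one place only, as 5-aminopyridin-3-yl in place of 6-aminopyridin-3-yl on a saturated ring carbon shows: 5-aminopyridin-3-yl stands in place of 6-aminopyridin-3-yl on a saturated ring carbon.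

Three measured steps exist, and all of them change the group on a carbonyl carbon. Oxan-4-yl in place of 3-fluorophenyl gave a 9.7-fold higher number from compound 1 to compound 2 (0.99 log units; beyond the scatter) and ethyl in place of 3-fluorophenyl gave a 24-fold higher number from compound 1 to compound 3 (1.38 log units; beyond the scatter) while ethyl in place of oxan-4-yl gave a 2.5-fold higher number from compound 2 to compound 3 (0.39 log units; beyond the scatter) in the same read-out. These steps range from modest to large, but none touches the group that changes here, so none bears directly on this swap. Within the data shown here, the data hold no example of moving the amino group on the pyridine ring.

Among the measured compounds shown here, compound 4 keeps the 3-fluorophenyl group, so the starting point remains compound 1 at 32000 nM as the only guide. The expected change is no change at the digits printed from compound 1 to compound 4 (within the scatter) and no step beyond the scatter is expected in either direction. For the measured compounds named here, the estimate for compound 4 is 32000 nM with 10000 nM to 100000 nM as the expected range, kept wide because no measured step covers this change.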

Compound 4, solubility: 17000 nM
Estimate against measurement, compound 4: 1.9-fold (0.27 log units) above; the range from low to high includes it.
By their numbers in this assay, from the lowest: compounds 4 and 1 (each within the scatter of the next); then compound 2; then compound 3.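

In this assay, 5-aminopyridin-3-yl in place of 6-aminopyridin-3-yl on the saturated ring carbon gives a 1.9-fold lower number from compound 1 to compound 4 (0.27 log units; within the scatter), the first step shown at this position, as every earlier step changed the group on a carbonyl carbon. With the 3-fluorophenyl group held constant, these two isomers, which have the same atoms joined differently, cannot be told apart in this read-out, whereas all three steps on the carbonyl carbon lie beyond the scatter. Nothing measured alongside these compounds offers an explanation for this result.

The compounds shown pair the two aminopyridinyl groups only with 3-fluorophenyl on the carbonyl carbon, so it remains open whether the same swap would read alike with oxan-4-yl or ethyl there. Also open, on these data alone, is how the number would respond at this position to a hydroxyl group, a dimethylamino group or a carboxylic acid in place of the amino group of 5-aminopyridin-3-yl.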